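From Methoxy to Amino on a Shared Chain

A few compounds are considered here, and "the series" means these few. Any claim that something is new, unique, unknown or untested is made for them only; others in the source may bear on it.

In a functional assay on HCT-116 cells (Homo sapiens) for antiproliferative activity, read by MTT assay, with a stated time of 48 h (a lower number here means a stronger inhibitor, a higher number a weaker inhibitor), compound 3 (`CCCCCCCCCCC(CCO)n1cnc2c(OC)ncnc21`) gives 7530 nM as its reading and compound 2 (`CCCCCCCCCC(CCO)n1cnc2c(N)ncnc21`) gives 10500 nM as its reading, so these two sit within the usual scatter of each other. In this assay compound 1 (`CCCCCCCC(CCO)n1cnc2c(N)ncnc21`) reads > 50000 nM and this is a limit of the assay, not a number.

The compound still to be measured, compound 4 (`CCCCCCCCCCC(CCO)n1cnc2c(N)ncnc21`), keeps the chain of compound 3 but carries amino in place of methoxy on an aromatic carbon. For the measured compounds named here, no measured step makes this swap directly. Going by the values given here, the only measured step is a chain change among the amino compounds, ethyl in place of hydrogen on a saturated chain carbon. In this assay it gave an at least 4.7-fold lower number from compound 1 to compound 2 (0.67 log units; beyond the scatter) and so lies beyond the scatter, but it says nothing direct about swapping methoxy for amino.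

The best guide is therefore the close agreement of the amino compound 2 at 10500 nM with the methoxy compound 3 at 7530 nM in the same readout. A step beyond the scatter is not expected, and the estimate leans only slightly towards a lower number: the expected change is a 1.3-fold lower number from compound 3 to compound 4 (0.10 log units; within the scatter) in this comparison. Compound 4 is expected in this assay to read 6000 nM (estimated range 2500 nM to 15000 nM).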

Compound 4, half-maximal inhibitory concentration: 2590 nM
Estimate against measurement, compound 4: 2.3-fold (0.36 log units) above, within the range that was stated.
By their numbers in this assay, from the lowest: compound 4; then compounds 3 and 2 (each within the scatter of the next). At a limit, above all of these: compound 1.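

For the compounds shown here, with the chain held the same, the group on this aromatic carbon now proves to matter: in this assay, amino in place of methoxy gives a 2.9-fold lower number from compound 3 to compound 4 (0.46 log units; beyond the scatter), and no earlier pair had isolated this swap on a single chain. The amino compounds also extend the earlier chain trend, with a 4.1-fold lower number from compound 2 to compound 4 (0.61 log units; beyond the scatter) and an at least 19-fold lower number from compound 1 to compound 4 (1.28 log units; beyond the scatter), so the number falls at each chain extension across compounds 1, 2 and 4, and none of the three goes against this. Compound 1 stands at a limit of the assay rather than at a number, which makes its step a bound and not an exact size: the limit of > 50000 nM in this assay, at which 1 of the 4 values shown sits.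

With only one methoxy compound shown, it remains open whether the swap gives a similar step on a shorter or longer chain, and whether the hydrogen-bond donor that amino has and methoxy lacks plays any part in it. Also open, going by these compounds, is what a longer chain than that of compound 4 would do, or what a methylamino or hydroxyl group would do on the same aromatic carbon.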